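This account rests on a few compounds, and the source may have more. Where it says the series, first, only, none or still open, it means among the compounds named here.

Compound 2 `O=Cc1ccc(-c2cn3ccnc3c(-c3ccc4ncn(C5CCCCC5)c4c3)n2)cc1` carries a 4-formylphenyl group on the shared core. For the measured compounds named here, in a functional assay on RXF 393 cells (Homo sapiens) for inhibition, read by sulforhodamine B assay, with a stated time of 48 h, tested at 10 uM (a lower number here means less inhibition, a higher number more inhibition at the concentration tested (going by the name of the read-out)), compound 2 gives 25%, the second highest of the three numbers measured so far. Compound 3 `Brc1ccc(-c2cn3ccnc3c(-c3ccc4ncn(C5CCCCC5)c4c3)n2)cc1` gives 34%, and compound 1 `Brc1cn2ccnc2c(-c2ccc3ncn(C4CCCCC4)c3c2)n1`, which bears only a bromo at that place, gives 5.58%. Replacing that bromo with a phenyl ring gave a number 19.4 percentage points higher from compound 1 to compound 2 (beyond the scatter) and a number 28.4 percentage points higher from compound 1 to compound 3 (beyond the scatter), whereas exchanging one group on the phenyl ring gave a number 9 percentage points higher from compound 2 to compound 3 (within the scatter). Compound 4 `COc1ccccc1-c1cn2ccnc2c(-c2ccc3ncn(C4CCCCC4)c3c2)n1` differs from compound 2 as follows: 2-methoxyphenyl in place of 4-formylphenyl on an aromatic carbon. Because the step of a number 9 percentage points higher from compound 2 to compound 3 (within the scatter) stayed within the scatter, another exchange of this kind is expected to move this assay little. The estimate for compound 4 is 25%, between 8% and 45%. That corresponds to an expected step of no change at the digits printed from compound 2 to compound 4 (within the scatter).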

Compound 4, a percentage reported as inhibition, at one concentration (the size of the read-out at that concentration, not a potency): 0.95%
Compound 4: middle estimate off by 24.1 percentage points, on the high side; measured number outside the range, below it.
By their numbers in this assay, from the lowest: compounds 4 and 1 (each within the scatter of the next); then compounds 2 and 3 (each within the scatter of the next).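

In this assay, a phenyl ring at this place does not by itself raise the number: 2-methoxyphenyl gives a number 24.1 percentage points lower from compound 2 to compound 4 (beyond the scatter) and a number 33.1 percentage points lower from compound 3 to compound 4 (beyond the scatter) when set against the two para-substituted rings named 4-formylphenyl and 4-bromophenyl. Set against the plain bromo, it gives a number 4.6 percentage points lower from compound 1 to compound 4 (within the scatter) and so shows no gain from adding this ring. No measured evidence here explains this result. Going by these compounds, it remains open whether the outcome belongs to the methoxy group itself or to where it sits on the ring. A 4-methoxyphenyl or 4-aminophenyl group at this place would help separate the two.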